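The source may hold more compounds than are shown below. What is called first, only, known or untested is meant among the compounds shown, and "the series" means these compounds.

Compound 1, `COc1ccc(C(=O)c2ccc(OC)c3c2C=CC(C)(C)O3)c(NC(=O)CN)c1`, gives 890 nM in a functional assay on A2780 cells (Homo sapiens) for antiproliferative activity, read by MTT assay, with a stated time of 48 h; a lower number here means a stronger inhibitor, a higher number a weaker inhibitor.
Compound 2, `CNCC(=O)Nc1cc(OC)ccc1C(=O)c1ccc(OC)c2c1C=CC(C)(C)O2`, gives 1590 nM.
Compound 3, `C=C(c1ccc(OC)cc1NC(=O)CN)c1ccc(OC)c2c1OC(C)(C)C=C2`, gives 80 nM.

Compound 2 differs from compound 1 by one change, (methyl in place of hydrogen on an amine nitrogen), and the step it made was a 1.8-fold higher number from compound 1 to compound 2 (0.25 log units; within the scatter). Compound 3 rests on another core; the difference between the core of compound 1 and the core of compound 3 is not broken down here, but compound 3 stands apart from both compound 1 and compound 2 by steps beyond the scatter. Compound 4, `C=C(c1ccc(OC)cc1NC(=O)CNC)c1ccc(OC)c2c1OC(C)(C)C=C2`, carries the same change on this core: methyl in place of hydrogen on an amine nitrogen. Since the earlier step is a 1.8-fold higher number from compound 1 to compound 2 (0.25 log units; within the scatter), the step from compound 3 to compound 4 is expected to be of similar size, a 1.8-fold higher number from compound 3 to compound 4 (0.24 log units; within the scatter). Compound 4 is therefore estimated at 140 nM, most likely between 60 nM and 350 nM.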

Compound 4, half-maximal inhibitory concentration: 210 nM
Compound 4: the middle estimate sits 1.5-fold (0.18 log units) below what was measured; the measured number falls inside the stated range.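

In this assay, methyl in place of hydrogen on the amine nitrogen gave a 2.6-fold higher number from compound 3 to compound 4 (0.42 log units; beyond the scatter). The same change on the other core gave a step that cannot be told apart from this one: the same change on two cores in this assay, a 1.8-fold higher number (0.25 log units; within the scatter) from compound 1 to compound 2 and a 2.6-fold higher number (0.42 log units; beyond the scatter) from compound 3 to compound 4, 1.5-fold (0.17 log units) apart, within the scatter of two such steps. So the change carried over from one core to the other with a similar effect on the number, but two pairs are a small sample, and they show neither why the number moves nor whether a third core would behave the same way.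

The compounds shown leave open what a larger group on this nitrogen, such as ethyl, would do. They also leave open whether a longer chain in place of the aminomethyl would keep the activity.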